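Phenyl in place of a methyl-oxadiazole on the outer ring

The source may report more compounds than this note shows. Statements on the series, on what has been measured and on what is new or still open speak of the compounds shown alone.

Measured so far in an ADME assay on MT4 cells (Homo sapiens) for cytotoxicity; a higher number here means that more compound is tolerated, a lower number that less compound is tolerated:
- compound 1, `COC(=O)N[C@H](C(=O)NN(CCC[C@@](O)(Cc1ccccc1)C(=O)N[C@H]1c2ccccc2C[C@H]1O)Cc1ccc(Br)cc1)C(C)(C)C`: compound 1 gives > 10000 nM, which is a limit of the assay rather than a number.
- compound 2, `COC(=O)N[C@H](C(=O)NN(CCC[C@@](O)(Cc1ccccc1)C(=O)N[C@H]1c2ccccc2C[C@H]1O)Cc1ccc(-c2noc(C)n2)cc1)C(C)(C)C`: compound 2 gives > 10000 nM, again a limit and not a number.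

Compound 2 therefore stands at the top of what this assay can report, and the limit of > 10000 nM in this assay, at which 2 of the 2 values shown sit, shows that both values shown sit there. Among the measured compounds shown here, the only measured step, a step that the two limits leave unreadable from compound 1 to compound 2, is unreadable because both ends are limits, so it gives no guide to the size of any change.

Compound 3, `COC(=O)N[C@H](C(=O)NN(CCC[C@@](O)(Cc1ccccc1)C(=O)N[C@H]1c2ccccc2C[C@H]1O)Cc1ccc(-c2ccccc2)cc1)C(C)(C)C`, differs from compound 2 by phenyl in place of 5-methyl-1,2,4-oxadiazol-3-yl on an aromatic carbon. With no readable step to draw on, no change beyond the scatter is expected, and compound 3 is estimated to stay at the limit: 15000 nM, within 7000 nM to 30000 nM, a step that the limit leaves unreadable from compound 2 to compound 3.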

Compound 3, half-maximal cytotoxic concentration: 7500 nM
Estimate against measurement, compound 3: 2.0-fold (0.30 log units) above, within the range that was stated.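

In this assay compound 3 gives 7500 nM, the first result at this position that is a number and not a limit of the assay. Placing phenyl here gives an at least 1.3-fold lower number from compound 2 to compound 3 (0.12 log units; that floor lies within the scatter), and the same phenyl gives an at least 1.3-fold lower number from compound 1 to compound 3 (0.12 log units; that floor lies within the scatter), so neither floor shows a change beyond the usual scatter. Compound 1 and compound 2 remain limits rather than numbers, and the true size of either step stays unknown: the limit of > 10000 nM in this assay, at which 2 of the 3 values shown sit.

The compounds shown leave open whether an amine or a carboxylic acid at this position would give a readable number or stay at the limit. They also leave open whether a pyridyl ring, which keeps a six-membered aromatic ring but puts a nitrogen into it, would give a number close to that of compound 3.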